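Trimming One Methoxy From Compound 2

The compounds below may be only part of what the source reports. "The series", "measured", "known", "first", "only" and "open" are said of these compounds alone.

In a functional assay on HCT-116 cells (Homo sapiens) for cytotoxicity, read by scintillation counting and thymidine incorporation, with a stated time of 72 h (on this read-out higher numbers stand for weaker inhibition and lower numbers for stronger inhibition), compound 1 (`COc1cc(OC)cc(C(=CC#N)c2ccc(OC)c(OC)c2)c1`) gives 18 nM. Compound 2 (`COc1cc(C(=CC#N)c2cc(OC)c(OC)c(OC)c2)cc(OC)c1OC`) reads > 10000 nM, which is a limit of the assay and not a number. Compound 3 (`COc1ccc(C(=CC#N)c2cc(OC)c(OC)c(OC)c2)cc1OC`) differs from compound 2 by a single change, hydrogen in place of methoxy on an aromatic carbon. Within the data shown here, no measured pair shows this change, so the expectation leans on compound 1 at 18 nM. A large step towards stronger inhibition is expected (an at least 33-fold lower number from compound 2 to compound 3 (1.52 log units; beyond the scatter)). Compound 3 is estimated at 300 nM, with an expected range of 30 nM to 5000 nM.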

Compound 3, half-maximal inhibitory concentration: 41 nM
Beside the measured number, compound 3's estimate is 7.3-fold (0.86 log units) above it, within the range that was stated.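

In this assay, taking away this one methoxy, on an aromatic carbon ortho to a methoxy group, gives an at least 240-fold lower number from compound 2 to compound 3 (2.38 log units; beyond the scatter) and brings the read-out into the measurable range. Compound 2 reads at a limit of the assay and not a number: the limit of > 10000 nM in this assay, at which 1 of the 3 values shown sits. With a 2.3-fold higher number from compound 1 to compound 3 (0.36 log units; beyond the scatter) as the only cost of methoxy in place of hydrogen on an aromatic carbon, a further methoxy is tolerated up to compound 3, and the heavy loss appears only with the extra methoxy of compound 2.

The compounds shown leave open how a hydroxyl, a fluorine or an amine would read on this carbon. They also leave open whether the same holds on the other aromatic ring.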